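Methoxy in place of butyl: what to expect

The source may report more compounds than this note shows. Statements on the series, on what has been measured and on what is new or still open speak of the compounds shown alone.

compound 1 `CCCCNc1ccc([N+](=O)[O-])cc1S(N)(=O)=O`: 85000 nM
compound 2 `CCCCCCCCNc1ccc(C(=O)O)cc1S(=O)(=O)NC`: 53000 nM
compound 3 `CCCCCCCCNc1ccc(C(=O)O)cc1S(=O)(=O)N(C)C`: 52000 nM

In a physicochemical assay for solubility, in phosphate buffer, measured as kinetic solubility, at pH 7.4, tested at 250 uM (on this read-out lower numbers stand for lower solubility and higher numbers for higher solubility), compound 3 gives 52000 nM, a number within the usual scatter of those for compound 1 and compound 2, so these three cannot be ranked. Compound 4 `COCCCCNc1ccc(C(=O)O)cc1S(=O)(=O)N(C)C` has not yet been measured. It keeps the core of compound 3 and differs in one place: methoxy in place of butyl on a saturated chain carbon, four bonds along the chain from a nitrogen on an aromatic ring. In words, this is methoxy in place of butyl on a saturated chain carbon, four bonds along the chain from a nitrogen on an aromatic ring.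

Among the compounds with values here, only one measured step exists here: a 1.0-fold lower number from compound 2 to compound 3 (0.01 log units; within the scatter). It lies within the scatter, but it concerns methyl in place of hydrogen on a sulfonamide nitrogen, so it says little about the chain. Within the data shown here, no measured pair tests this change directly. The loosest of hints comes from compound 1, which has a butyl chain and differs from compound 3 in more than one place. Compound 1 reads 85000 nM. A modest move to a higher number is therefore expected, with wide uncertainty. The estimate means a 2.3-fold higher number from compound 3 to compound 4 (0.36 log units; beyond the scatter), an expected step and not a measured one. The expected value for compound 4 is 120000 nM, with an estimated range from 55000 nM to 250000 nM.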

Compound 4, solubility: 247000 nM
Beside the measured number, compound 4's estimate is 2.1-fold (0.31 log units) below it; measured number inside the range.
By their numbers in this assay, from the lowest: compounds 3, 2 and 1 (each within the scatter of the next); then compound 4.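

In this assay, within the data shown here, the swap at the chain end gives a 4.8-fold higher number from compound 3 to compound 4 (0.68 log units; beyond the scatter) and is the first single change here to go beyond the scatter. The only earlier step, a 1.0-fold lower number from compound 2 to compound 3 (0.01 log units; within the scatter) at a sulfonamide nitrogen, stayed within it, so this place on the chain, four bonds along from a nitrogen on an aromatic ring, is the first shown to move the number. The swap both removes carbons and adds an oxygen, and nothing measured here separates the two or gives a reason for the rise.

Compound 4 gives 247000 nM in a read-out tested only slightly higher, so a larger step may not be visible in this assay at all. Also open, as far as these compounds go, is whether a hydroxyl or an amine at the chain end, or a longer chain carrying the methoxy, would behave in the same way.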